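Iodo for Bromo on the Benzamide Ring of Compound 3

The source may hold more compounds than are shown below. What is called first, only, known or untested is meant among the compounds shown, and "the series" means these compounds.

Compound 1, `NC(=O)c1c(NC(=O)c2ccccc2Cl)sc2c1CCN(C(=S)Nc1ccccc1C(F)(F)F)C2`: in a functional assay on HeLa cells (Homo sapiens) for antiproliferative activity, with a stated time of 24 h (a higher number here means a weaker inhibitor, a lower number a stronger inhibitor), compound 1 gives 26700 nM.
Compound 2, `NC(=O)c1c(NC(=O)c2ccccc2Br)sc2c1CCN(C(=S)Nc1ccccc1F)C2`: compound 2 reaches only > 50000 nM, which is a limit of the assay and not a number.
Compound 3, `NC(=O)c1c(NC(=O)c2ccccc2Br)sc2c1CCN(C(=S)Nc1ccccc1C(F)(F)F)C2`: compound 3 gives 39600 nM.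

Compound 3 stands at the highest of the two numbers shown. Its nearest neighbour is compound 1, and the step of a 1.5-fold higher number from compound 1 to compound 3 (0.17 log units; within the scatter) lies within the scatter. Against compound 2 the step of an at least 1.2-fold lower number from compound 2 to compound 3 (0.10 log units; that floor lies within the scatter) has only a floor, and that floor also lies within the scatter. Compound 2 itself sits at the limit of > 50000 nM in this assay, at which 1 of the 3 values shown sits.

Compound 4, `NC(=O)c1c(NC(=O)c2ccccc2I)sc2c1CCN(C(=S)Nc1ccccc1C(F)(F)F)C2`, has not yet been measured. It differs from compound 3 in one place: iodo in place of bromo on an aromatic carbon. Among the compounds with values here, the only measured step of a similar kind, one halogen exchanged for another, is a 1.5-fold higher number from compound 1 to compound 3 (0.17 log units; within the scatter), which stayed within the scatter. Compound 4 is therefore expected to differ from compound 3 by no more than the scatter. The expected step is a 1.0-fold higher number from compound 3 to compound 4 (0.00 log units; within the scatter). Compound 4 is estimated at 40000 nM, with a range from 20000 nM to 80000 nM.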

Compound 4, half-maximal inhibitory concentration: 49200 nM
Compound 4: the middle estimate sits 1.2-fold (0.09 log units) below what was measured; measured number inside the range.
By their numbers in this assay, from the lowest: compounds 1, 3 and 4 (each within the scatter of the next). At a limit, above all of these: compound 2.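

With iodo on this aromatic carbon, three halogens have now been read at the same place, and in this assay this exchange, a 1.2-fold higher number from compound 3 to compound 4 (0.09 log units; within the scatter), behaves like the chloro to bromo exchange before it. The widest span among the three, a 1.8-fold higher number from compound 1 to compound 4 (0.27 log units; within the scatter), also stays within the scatter, so chloro, bromo and iodo cannot be told apart here across compound 1, compound 3 and compound 4. Compound 2 remains at a limit of the assay and not a number: the limit of > 50000 nM in this assay, at which 1 of the 4 values shown sits.

The compounds shown leave open whether a group other than a halogen at this place, such as methoxy, an amine or a carboxylic acid, would move the number beyond the scatter. Also open, from the compounds shown here alone, is how iodo would read with fluoro in place of trifluoromethyl.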